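Swapping Benzyl for Propoxy on a Cell-Safe Amide

A few compounds are considered here, and "the series" means these few. Any claim that something is new, unique, unknown or untested is made for them only; others in the source may bear on it.

In an ADME assay on Vero cells (Chlorocebus sabaeus) for cytotoxicity, read by resazurin assay, with a stated time of 3 days (a higher number here means a weaker inhibitor, a lower number a stronger inhibitor), compound 1 (`O=C(CCc1ccccc1)Nc1cc2nc(C3CCCCC3)[nH]c2cc1N1CCCC1`) gives > 100 ug/mL as its reading, and this is a limit of the assay, not a number. Compound 2 (`CCCc1ccc(C(=O)Nc2cc3nc(C4CCCCC4)[nH]c3cc2N(C)C)cc1`) gives > 100 ug/mL as its reading, which is again a limit. Compound 1 therefore offers no exact value to start from.

Compound 3 (`CCCOCC(=O)Nc1cc2nc(C3CCCCC3)[nH]c2cc1N1CCCC1`) keeps the core of compound 1 and changes one group, with propoxy in place of benzyl on a saturated chain carbon bound to a carbonyl carbon as the whole difference. Going by the values given here, no pair of measured compounds shows what such a swap does, so in this assay the expectation is a step no larger than the usual scatter, in neither direction. That expectation rests on compound 1 and compound 2 alone, whose readings are the limit of > 100 ug/mL in this assay, at which 2 of the 2 values shown sit, and give only a loose guide. As a number, the expected change is a number no higher from compound 1 to compound 3 (the limit leaves the size open) and it remains an estimate. For compound 3 the estimated value is 100 ug/mL with an expected range from 40 ug/mL to 200 ug/mL in this test.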

Compound 3, half-maximal inhibitory concentration: > 100 ug/mL
Compound 3: no number, only a limit; the forecaster's own chance of this, stated with the estimate: 70%; the middle value sits exactly at the limit.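

Going by these compounds alone, compound 1 and compound 3 both read as a limit of the assay rather than a number, so no step between them can be read: the limit of > 100 ug/mL in this assay, at which 3 of the 3 values shown sit.

In this assay the compounds shown leave open how far each one lies past that limit, and whether propoxy in place of benzyl changes the reading at all.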